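The source may report more compounds than this note shows. Statements on the series, on what has been measured and on what is new or still open speak of the compounds shown alone.

Compound 1 `O=C(/C=C/c1csc2ccccc12)c1cc(Br)ccc1O`: 660 nM
Compound 2 `Cc1ccc(O)c(C(=O)/C=C/c2csc3ccccc23)c1`: 4800 nM

Both compounds were tested in a functional assay on A549 cells (Homo sapiens) for antiproliferative activity, read by sulforhodamine B assay, with a stated time of 72 h; a lower number here means a stronger inhibitor, a higher number a weaker inhibitor. Compound 2, at 4800 nM, has the higher of the two numbers, which makes it the weaker inhibitor. Compound 3 `CCOc1ccc(O)c(C(=O)/C=C/c2csc3ccccc23)c1` keeps the shared core but carries ethoxy in place of methyl on an aromatic carbon, para to a hydroxy group (ethoxy in place of methyl on an aromatic carbon).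

Within the data shown here, only one measured step bears on this change: a 7.3-fold higher number from compound 1 to compound 2 (0.86 log units; beyond the scatter). It involves the same place on the ring, so substituents there can matter, but it was a swap of bromo for methyl. Among the measured compounds shown here, no measured compound carries ethoxy, so the data give only a weak guide. A shift no larger than that step is expected, leaning slightly towards a lower number. The estimated change is a 1.6-fold lower number from compound 2 to compound 3 (0.20 log units; within the scatter). For compound 3 the expected value is 3000 nM, with an estimated range of 800 nM to 10000 nM.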

Compound 3, half-maximal inhibitory concentration: 5400 nM
Beside the measured number, compound 3's estimate is 1.8-fold (0.26 log units) below it, within the range that was stated.
By their numbers in this assay, from the lowest: compound 1; then compounds 2 and 3 (each within the scatter of the next).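

In this assay the exchange of methyl for ethoxy gives a 1.1-fold higher number from compound 2 to compound 3 (0.05 log units; within the scatter), so at this position, para to a hydroxy group, going from 1 heavy atom to 3 heavy atoms, one of them an oxygen, leaves the number within the scatter. Exchanging bromo for ethoxy gives an 8.2-fold higher number from compound 1 to compound 3 (0.91 log units; beyond the scatter), so compound 1 now stands apart from both compound 2 and compound 3, and of the three groups at this position only bromo goes with a clearly lower number. No measurement shown here explains this difference.

On these data alone, whether another halogen such as chlorine would also give a lower number remains open. So does the outcome with an amine, a carboxylic acid or a longer chain such as butoxy at this position.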